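This account rests on a few compounds, and the source may have more. Where it says the series, first, only, none or still open, it means among the compounds named here.

Measured compounds:
- Compound 1, `COC(=O)C1=C(C)NC(C)=C(C(=O)OCC(C)[N+](=O)[O-])C1c1cccc([N+](=O)[O-])c1`, gives 111 nM in a functional assay on HEK293 cells for antagonist activity at Voltage-dependent L-type calcium channel subunit alpha-1D (Rattus norvegicus), read by FLIPR; a lower number here means a stronger inhibitor, a higher number a weaker inhibitor.
- Compound 2, `C=C(C)C(=O)OCCOC(=O)C1=C(C)NC(C)=C(C(=O)OCC)C1c1cccc([N+](=O)[O-])c1`, gives 10 nM in this assay.

Of these two, compound 1 stands at the higher value, so it is the weaker inhibitor of the pair; the gap down to compound 2 lies beyond the scatter of the assay. Compound 3, `COC(=O)C1=C(C)NC(C)=C(C(=O)OCc2ccc(-c3ccccc3)cc2)C1c1cccc([N+](=O)[O-])c1`, has not yet been measured. It differs from compound 1 in one place: 4-phenylphenyl in place of 1-nitroethyl on a saturated chain carbon bound to an oxygen next to a carbonyl group. This is a change at the ester side of the shared core, and compound 2 shows that a different ester in that part of the molecule can give a clearly lower value than compound 1 gives. Among the measured compounds shown here, no direct pair of measured compounds covers this particular exchange, so the expectation rests only on that comparison. For compound 3 the step of a 3.7-fold lower number from compound 1 to compound 3 (0.57 log units; beyond the scatter) in this assay is expected to go toward a lower value. Compound 3 is therefore estimated at 30 nM, within a range of 5 nM to 200 nM.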

Compound 3, half-maximal inhibitory concentration: 74 nM
Estimate against measurement, compound 3: 2.5-fold (0.39 log units) below, and the stated range covers the measured number.
By their numbers in this assay, from the lowest: compound 2; then compounds 3 and 1 (each within the scatter of the next).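

In this assay, putting 4-phenylphenyl in place of 1-nitroethyl gives a 1.5-fold lower number from compound 1 to compound 3 (0.18 log units; within the scatter), and that step is within the scatter. So at this place, on a saturated chain carbon bound to an oxygen next to a carbonyl group, a group of 5 heavy atoms with 2 hydrogen-bond acceptors and no ring can give way to one of 12 heavy atoms with two aromatic rings and no hydrogen-bond acceptors, with no measurable change in the number. Nothing available explains why such different groups read alike.

The compounds shown leave open whether a single phenyl ring, a longer chain, an amine or a carboxylic acid at this place would also stay within the scatter of compound 1. Among the compounds shown here, with only one exchange read here, no general rule for this position can yet be drawn.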